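Removing the ring chlorine from a weakly cytotoxic thiazole enone

This account rests on a few compounds, and the source may have more. Where it says the series, first, only, none or still open, it means among the compounds named here.

Compound 3 `Cc1cccc(Nc2nc(C)c(C(=O)/C=C/c3ccccc3Cl)s2)c1`: 24200 nM
Compound 1 `Cc1nc(Nc2ccc(Cl)cc2)sc1C(=O)/C=C/c1ccccc1`: > 25000 nM
Compound 2 `Cc1nc(Nc2cccc(Cl)c2)sc1C(=O)/C=C/c1ccccc1`: > 25000 nM

Going by the values given here, in a functional assay on BGC-823 cells (Homo sapiens) for cytotoxicity, read by MTT assay (a lower number here means a stronger inhibitor, a higher number a weaker inhibitor), compound 3 gives 24200 nM, the only actual number among the three measured compounds. For compound 1 this assay reports only a limit, > 25000 nM. For compound 2 the result is likewise a limit, > 25000 nM. The step that the two limits leave unreadable from compound 1 to compound 2 is therefore unreadable. Compound 3 stands just inside the range where the other two sit at the limit of > 25000 nM in this assay, at which 2 of the 3 values shown sit, so it is not separated from them by anything beyond the scatter.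

Compound 4 `Cc1cccc(Nc2nc(C)c(C(=O)/C=C/c3ccccc3)s2)c1` differs from compound 3 by hydrogen in place of chloro on an aromatic carbon, that is, 2-chlorophenyl becomes phenyl on the enone side. Among the compounds with values here, no measured step touches this change, since compounds 1 and 2 carry the plain phenyl together with a different aryl amine. What the values show is that all three measured compounds, with or without this chlorine, lie at or just below the limit of this assay. The expected step of a 1.2-fold higher number from compound 3 to compound 4 (0.09 log units; within the scatter) is therefore none beyond the scatter. Compound 4 is expected to give about 30000 nM in this assay, within a range of 12000 nM to 90000 nM, most likely reported as a limit.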

Compound 4, half-maximal inhibitory concentration: 13600 nM
Beside the measured number, compound 4's estimate is 2.2-fold (0.34 log units) above it, and the stated range covers the measured number.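

In this assay, removing the chlorine gives a 1.8-fold lower number from compound 3 to compound 4 (0.25 log units; within the scatter), so 2-chlorophenyl and phenyl are not told apart on the enone side. Compound 4 also gives a measured number on the plain phenyl series, where the other two compounds stop at a limit, and this allows two comparisons on the amine side: an at least 1.8-fold lower number from compound 2 to compound 4 (0.26 log units; that floor lies within the scatter) for methyl in place of chloro, and an at least 1.8-fold lower number from compound 1 to compound 4 (0.26 log units; that floor lies within the scatter) for 3-methylphenyl in place of 4-chlorophenyl. Both are floors set by that limit rather than measured sizes: the limit of > 25000 nM in this assay, at which 2 of the 4 values shown sit.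

The compounds shown leave open whether a different group on the enone phenyl, such as methoxy or dimethylamino, would shift the value beyond the scatter. They also leave open how a carboxylic acid or a hydroxyl in place of the methyl on the amine-side ring would read here.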